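The compounds below may be only part of what the source reports. "The series", "measured", "known", "first", "only" and "open" are said of these compounds alone.

Compound 1 `C/C(=N\NC(=O)c1cccc(S(=O)(=O)N2CCOCC2)c1)c1cccc(N)c1` in a functional assay on ECa-109 cells for antiproliferative activity against ECa-109 cell line (Homo sapiens), read by MTT assay, with a stated time of 72 h (a lower number here means a stronger inhibitor, a higher number a weaker inhibitor), gives > 100000 nM, which is a limit of the assay rather than a number.
Compound 2 `C/C(=N\NC(=O)c1cccc(S(=O)(=O)N2CCOCC2)c1)c1cccc(N)c1O` in this assay gives 5060 nM.
Compound 3 `O=C(N/N=C/c1ccccn1)c1cccc(S(=O)(=O)N2CCOCC2)c1` in this assay gives 55700 nM.

Of the two numbers measured, compound 3 holds the higher one, so it is the weaker of those two inhibitors. Compound 4 `CCOc1cccc(/C=N/NC(=O)c2cccc(S(=O)(=O)N3CCOCC3)c2)c1O` has not yet been measured; it differs from compound 3 by 3-ethoxy-2-hydroxyphenyl in place of pyridin-2-yl on a carbon with a double bond to nitrogen. Among the compounds with values here, the only measured step, an at least 19-fold lower number from compound 1 to compound 2 (1.29 log units; beyond the scatter), shows that a hydroxy placed on the aromatic ring brought a large gain. Since the ring entering in compound 4 also carries a hydroxy, a gain in the same direction is expected for compound 4 on the strength of an at least 19-fold lower number from compound 1 to compound 2 (1.29 log units; beyond the scatter), though the ring changes in other ways too. Compound 4 is therefore expected to give 4000 nM, between 600 nM and 25000 nM, an expected step of a 14-fold lower number from compound 3 to compound 4 (1.14 log units; beyond the scatter).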

Compound 4, half-maximal inhibitory concentration: 16500 nM
Beside the measured number, compound 4's estimate is 4.1-fold (0.62 log units) below it; the range from low to high includes it.
By their numbers in this assay, from the lowest: compound 2; then compound 4; then compound 3. At a limit, above all of these: compound 1.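

On a carbon with a double bond to nitrogen, 3-ethoxy-2-hydroxyphenyl in place of pyridin-2-yl brings a 3.4-fold lower number from compound 3 to compound 4 (0.53 log units; beyond the scatter), so this position accepts a larger, carbon-only ring, with a modest gain. The change replaces the ring and adds the hydroxy and the ethoxy all at once, so the step cannot be credited to any one of them. Nothing measured here explains the step. Still open, going by these compounds, is what a phenyl ring carrying only the hydroxy or only the ethoxy would give, and what an amine or a carboxylic acid would give in place of the hydroxy.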